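Aryl urea ACAT inhibitors: swapping a para substituent

This account rests on a few compounds, and the source may have more. Where it says the series, first, only, none or still open, it means among the compounds named here.

Measured compounds:
compound 1 `COc1cccc(C2(CNC(=O)Nc3c(C(C)C)cccc3C(C)C)CCCC2)c1` — 13 nM
compound 2 `CC(C)c1cccc(C(C)C)c1NC(=O)NCC1(c2ccc(C(F)(F)F)cc2)CCCC1` — 66 nM

In an assay on microsomes for inhibition of acyl-CoA:cholesterol acyltransferase (Oryctolagus cuniculus) (on this read-out lower numbers stand for stronger inhibition and higher numbers for weaker inhibition), compound 1 gives 13 nM. Compound 2 gives 66 nM in this assay, which is the higher of the two numbers shown; the only measured step, a 5.1-fold higher number from compound 1 to compound 2 (0.71 log units; beyond the scatter), separates it from compound 1.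

Compound 3 `CC(C)c1cccc(C(C)C)c1NC(=O)NCC1(c2ccc(N)cc2)CCCC1` is not yet measured. It differs from compound 2 by amino in place of trifluoromethyl on an aromatic carbon, a change on the aromatic carbon para to a large group. Within the data shown here, no measured step covers an amino group on this ring, so the expectation rests on a single loose parallel: the step from compound 1 to compound 2 shows that exchanging the substituent on this phenyl ring can shift the number beyond the scatter, but in that step the position on the ring moved as well, so it does not tell the direction for compound 3. Compound 3 is therefore expected to land near compound 2, with a modest upward shift estimated as a 2.3-fold higher number from compound 2 to compound 3 (0.36 log units; beyond the scatter). The estimate for compound 3 is 150 nM, within 40 nM to 600 nM.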

Compound 3, half-maximal inhibitory concentration: 29 nM
Compound 3: the middle estimate sits 5.2-fold (0.71 log units) above what was measured; measured number below the stated range.
By their numbers in this assay, from the lowest: compound 1; then compound 3; then compound 2.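

In this assay, amino in place of trifluoromethyl on the aromatic carbon para to a large group gives a 2.3-fold lower number from compound 2 to compound 3 (0.36 log units; beyond the scatter). Among these compounds, this is the first step that changes the group while it stays at one ring position, and it shows that the group alone moves the number beyond the scatter, here towards stronger inhibition. The 4-aminophenyl group still falls short of the 3-methoxyphenyl group, with a 2.2-fold higher number from compound 1 to compound 3 (0.35 log units; beyond the scatter), and nothing shown bears on why the numbers fall in this order.

One pair at a single position cannot tell whether the lower number belongs to amino in particular or would also appear with a hydroxyl, a methoxy or a dimethylamino group on the same aromatic carbon. From the compounds shown here alone, since the step to the 3-methoxyphenyl group changes both the group and its place on the ring, it also remains open how much of that gap belongs to each, which a methoxy group on the aromatic carbon para to a large group, or an amino group placed as the methoxy group is in compound 1, would begin to separate.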